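The source may hold more compounds than are shown below. What is called first, only, known or untested is meant among the compounds shown, and "the series" means these compounds.

Compound 1 `C=CC(=O)Nc1cccc(NC(=O)CSc2nc(Nc3ccccc3Cl)c3ccccc3n2)c1` gives 20700 nM in a functional assay on MGC-803 cells (Homo sapiens) for inhibition, read by MTT assay, with a stated time of 72 h; a higher number here means a weaker inhibitor, a lower number a stronger inhibitor. Compound 2 `C=CC(=O)Nc1cccc(NC(=O)CSc2nc(Nc3ccc(Cl)c(Cl)c3)c3ccccc3n2)c1` carries the 3,4-dichlorophenyl in place of the 2-chlorophenyl; in this assay compound 2 reports only a limit of the assay, > 50000 nM. Going by the values given here, the single measured step, an at least 2.4-fold higher number from compound 1 to compound 2 (0.38 log units; beyond the scatter), is therefore known only as a lower bound, set by the limit of > 50000 nM in this assay, at which 1 of the 2 values shown sits. Compound 2 thus stands at the weak end of the two numbers shown, and only a limit is known for it.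

Compound 3 `C=CC(=O)Nc1cccc(NC(=O)CSc2nc(Nc3ccc(F)c(Cl)c3)c3ccccc3n2)c1` differs from compound 2 by fluoro in place of chloro on an aromatic carbon, ortho to a chloro group and para to a large group. Among the compounds with values here, no measured step bears directly on this exchange; the one step at hand, an at least 2.4-fold higher number from compound 1 to compound 2 (0.38 log units; beyond the scatter), concerns a different change on the same ring and says only that the dichloro pattern sits at or past the limit. Compound 3 is expected to stay near that limit, the step of a number no higher from compound 2 to compound 3 (the limit leaves the size open) being within the scatter. For compound 3 the estimate is 50000 nM, with a range of 20000 nM to 150000 nM.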

Compound 3, half-maximal inhibitory concentration: 7850 nM
Compound 3: the middle estimate sits 6.4-fold (0.80 log units) above what was measured; the whole stated range lies above it.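

Fluoro in place of chloro, on the carbon ortho to a chloro group and para to a large group, gives an at least 6.3-fold lower number from compound 2 to compound 3 (0.80 log units; beyond the scatter) in this assay, so this position responds to the exchange of one halogen for another. The 3-chloro-4-fluorophenyl group also compares well with the 2-chlorophenyl group, with a 2.6-fold lower number from compound 1 to compound 3 (0.42 log units; beyond the scatter), so moving away from 2-chlorophenyl does not weaken the series in every case, as the step to compound 2 alone might have suggested. The first of these steps remains a lower bound, and its true size is open: the limit of > 50000 nM in this assay, at which 1 of the 3 values shown sits.

A methyl, a methoxy or a nitrile on this carbon would help show whether the gain belongs to fluoro in particular or to the loss of chloro. Going by these compounds, whether the gain holds without the remaining chloro group, as in a 4-fluorophenyl group, also stays open.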